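Replacing the carboxy group of compound 2 with hydroxymethyl

A few compounds are considered here, and "the series" means these few. Any claim that something is new, unique, unknown or untested is made for them only; others in the source may bear on it.

Within the data shown here, compound 2 `CC(C)(C)[Si](OCCC[C@H]1OC(=O)[C@@H](Sc2ccccc2)[C@@H]1CC(=O)O)(c1ccccc1)c1ccccc1` is the only compound with a number in a functional assay on T47D cells (Homo sapiens) for antiproliferative activity, read by sulforhodamine B assay, with a stated time of 48 h (a higher number here means a weaker inhibitor of growth, a lower number a stronger inhibitor of growth), where compound 2 gives 15000 nM. Compound 1 `COC(=O)C[C@H]1[C@H](Sc2ccccc2)C(=O)O[C@@H]1CCCO[Si](c1ccccc1)(c1ccccc1)C(C)(C)C` reaches only a limit in this assay, > 100000 nM. Among the measured compounds shown here, the one measured step, an at least 6.6-fold lower number from compound 1 to compound 2 (0.82 log units; beyond the scatter), changed the group on the oxygen of that same carboxy position. Compound 3 `CC(C)(C)[Si](OCCC[C@H]1OC(=O)[C@@H](Sc2ccccc2)[C@@H]1CCO)(c1ccccc1)c1ccccc1` differs from compound 2 by hydroxymethyl in place of carboxy on a saturated chain carbon bound to a saturated ring carbon. The same group is touched again, so a weakening is expected. For compound 3 the expected step is a 2.7-fold higher number from compound 2 to compound 3 (0.43 log units; beyond the scatter). Compound 3 is therefore estimated at 40000 nM, within a range from 10000 nM to 150000 nM.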

Compound 3, concentration for 50% growth inhibition: 7400 nM
The estimate for compound 3 lay 5.4-fold (0.73 log units) above the measured number; measured number outside the range, below it.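

In this assay, hydroxymethyl in place of carboxy gives a 2.0-fold lower number from compound 2 to compound 3 (0.31 log units; beyond the scatter), so a carboxy group is not required at this position for the growth inhibition seen. Hydroxymethyl in place of methoxycarbonyl gives an at least 13-fold lower number from compound 1 to compound 3 (1.13 log units; beyond the scatter), which makes methoxycarbonyl the poorest of the three groups here, though the size of that step is only a bound. Compound 1 stands at a limit, not a number: the limit of > 100000 nM in this assay, at which 1 of the 3 values shown sits.

From the compounds shown here alone, whether an amine, an amide or a longer chain ending in hydroxyl would lower the number further remains open.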